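This account rests on a few compounds, and the source may have more. Where it says the series, first, only, none or still open, it means among the compounds named here.

Measured so far in an ADME assay (liver) for metabolic stability, with Liver microsome (Homo sapiens) as the target, using microsomes and NADPH, with a stated time of 30 min, tested at 1 uM; a higher number here means faster removal of the compound, a lower number slower removal:
- compound 1 `CC(C)(C)n1cc(-c2cc(C(O)(C(F)(F)F)C(F)(F)F)cnc2N2CCN(S(=O)(=O)c3ccc(N)nc3)CC2)cn1`: 86 mL.min-1.g-1
- compound 2 `Nc1ccc(S(=O)(=O)N2CCN(c3ncc(C(O)(C(F)(F)F)C(F)(F)F)cc3-c3ccc4ocnc4c3)CC2)cn1`: < 14 mL.min-1.g-1
- compound 3 `Nc1ccc(S(=O)(=O)N2CCN(c3ncc(C(O)(C(F)(F)F)C(F)(F)F)cc3-c3ccc4c(c3)CC(=O)N4)CC2)cn1`: < 14 mL.min-1.g-1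

Among the compounds with values here, compound 1 is the only compound of the three with a number rather than a limit in this assay. Compound 2 sits at a limit of this assay, with < 14 mL.min-1.g-1. Compound 3 likewise sits at a limit, with < 14 mL.min-1.g-1; this is the limit of < 14 mL.min-1.g-1 in this assay, at which 2 of the 3 values shown sit.

Compound 4 `Nc1ccc(S(=O)(=O)N2CCN(c3ncc(C(O)(C(F)(F)F)C(F)(F)F)cc3-c3ccc4[nH]ncc4c3)CC2)cn1` is not yet measured. It differs from compound 1 in one place: 1H-indazol-5-yl in place of 1-(tert-butyl)-1H-pyrazol-4-yl on an aromatic carbon.

Within the data shown here, two measured steps bear on this change, since both also replace the 1-(tert-butyl)-1H-pyrazol-4-yl of compound 1 with a fused bicyclic aromatic group on the same aromatic carbon: an at least 6.1-fold lower number from compound 1 to compound 2 (0.78 log units; beyond the scatter) and an at least 6.1-fold lower number from compound 1 to compound 3 (0.78 log units; beyond the scatter). Both are lowerings that run past the scatter and end at the limit, so their full size is unreadable. The step from compound 2 to compound 3 cannot be read either, as both values are limits.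

For compound 4 a lowering of at least the same order is therefore expected, a 6.1-fold lower number from compound 1 to compound 4 (0.79 log units; beyond the scatter), with a fair chance that this assay again reports only a limit. The estimate for compound 4 is 14 mL.min-1.g-1, within a range from 5 mL.min-1.g-1 to 30 mL.min-1.g-1.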

Compound 4, intrinsic clearance in microsomes: 27 mL.min-1.g-1
For compound 4 the middle estimate is 1.9-fold (0.29 log units) below the measured one, and the stated range covers the measured number.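

In this assay compound 4 gives a number, not a limit, for a fused bicyclic group on this aromatic carbon, ortho to a large group, so the drop on leaving 1-(tert-butyl)-1H-pyrazol-4-yl now has a readable size: a 3.2-fold lower number from compound 1 to compound 4 (0.50 log units; beyond the scatter). Against the two other fused groups, the 1H-indazol-5-yl shows an at least 1.9-fold higher number from compound 2 to compound 4 (0.28 log units; that floor lies within the scatter) and an at least 1.9-fold higher number from compound 3 to compound 4 (0.28 log units; that floor lies within the scatter), but both floors lie within the scatter and no order among the three fused groups follows. Compound 2 and compound 3 each stand at a limit, so neither their full distance from compound 4 nor the step between them can be read: the limit of < 14 mL.min-1.g-1 in this assay, at which 2 of the 4 values shown sit.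

Each change shown replaces the tert-butyl group and the ring together, which leaves open how much of the step belongs to each, and a 1H-pyrazol-4-yl carrying a methyl group in place of the tert-butyl would help separate the two. Also open, going by these compounds, is whether a methyl group on the indazole nitrogen that now carries hydrogen would move the number in this assay.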